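The source may report more compounds than this note shows. Statements on the series, on what has been measured and on what is new or still open speak of the compounds shown alone.

Working notes on the series.

In an ADME assay (liver) for metabolic stability, with Liver microsome (Homo sapiens) as the target, using microsomes and NADPH, with a stated time of 30 min, tested at 1 uM (a higher number here means faster removal of the compound, a lower number slower removal), compound 2 `Nc1ccc(S(=O)(=O)N2CCN(c3ncc(C(O)(C(F)(F)F)C(F)(F)F)cc3-c3ccccc3O)CC2)cn1` gives 22 mL.min-1.g-1. Among the compounds with values here, this is the only number so far; the other entry is a limit. Compound 1 `Nc1ccc(S(=O)(=O)N2CCN(c3ncc(C(O)(C(F)(F)F)C(F)(F)F)cc3C#CCCO)CC2)cn1` returns only a limit of the assay in this assay, < 14 mL.min-1.g-1, which is the limit of < 14 mL.min-1.g-1 in this assay, at which 1 of the 2 values shown sits. Within the data shown here, the single measured step, an at least 1.5-fold higher number from compound 1 to compound 2 (0.19 log units; that floor lies within the scatter), thus has a floor that stays within the scatter, and its true size is open.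

Compound 3 `Nc1ccc(S(=O)(=O)N2CCN(c3ncc(C(O)(C(F)(F)F)C(F)(F)F)cc3-c3cc4ccccc4s3)CC2)cn1` differs from compound 2 by 1-benzothiophen-2-yl in place of 2-hydroxyphenyl on an aromatic carbon. Among the measured compounds shown here, the change sits in the same place as the one from compound 1 to compound 2, on an aromatic carbon of a six-membered aromatic ring with 1 nitrogen, two atoms from the ring nitrogen. For the measured compounds named here, no step yet exchanges one aromatic group for another of a different size, so the expectation rests on the direction of an at least 1.5-fold higher number from compound 1 to compound 2 (0.19 log units; that floor lies within the scatter) alone.

Compound 3 is expected to give 45 mL.min-1.g-1 in this assay, with a range of 15 mL.min-1.g-1 to 130 mL.min-1.g-1. Going by the values given here, the expected step of a 2.0-fold higher number from compound 2 to compound 3 (0.31 log units; beyond the scatter) is thus upward, and only moderately so, given that the one measured step was at least an at least 1.5-fold higher number from compound 1 to compound 2 (0.19 log units; that floor lies within the scatter).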

Compound 3, intrinsic clearance in microsomes: < 14 mL.min-1.g-1
Compound 3: no number, only a limit (the forecaster's own chance of this, stated with the estimate: 5%); middle value at least 3.2-fold (0.50 log units) from the limit.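

In this assay compound 3 returns a limit of the assay and not a number: the limit of < 14 mL.min-1.g-1 in this assay, at which 2 of the 3 values shown sit.

Replacing 2-hydroxyphenyl with 1-benzothiophen-2-yl, on the aromatic carbon two atoms from the ring nitrogen, gives an at least 1.5-fold lower number from compound 2 to compound 3 (0.19 log units; that floor lies within the scatter), so an aromatic group at this place does not by itself bring a measurable number, and among the groups shown here only 2-hydroxyphenyl gives one. The step between compound 1 and compound 3 joins two limits and cannot be read.

The compounds shown leave open whether the hydroxy group of 2-hydroxyphenyl, rather than the ring that carries it, sets compound 2 apart; a plain phenyl or a 2-methoxyphenyl at the same place would bear directly on that question. Also open, from the compounds shown here alone, are how far compound 1 and compound 3 lie beyond the limit, and so the true size of every step, and whether a pyridyl ring or a short amine chain at this place would give a number at all.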